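Rec1 series: acrylamide and crotonamide anilides compared

The source may hold more compounds than are shown below. What is called first, only, known or untested is meant among the compounds shown, and "the series" means these compounds.

Measured so far:
compound 1 `C/C=C/C(=O)N1CCCC(n2nc(-c3ccc(Oc4ccccc4)cc3)cc2C(=O)OCC)C1` — 5100 nM
compound 2 `C=CC(=O)Nc1cccc(Cn2nc(-c3ccc(Oc4ccccc4)cc3)cc2C(=O)OCC)c1` — 3300 nM

In a functional assay on Rec1 cells (Homo sapiens) for inhibition, read by luminescence and CellTiter-Glo, with a stated time of 72 h (a lower number here means a stronger inhibitor, a higher number a weaker inhibitor), compound 2 gives 3300 nM, the lowest of the two numbers, while compound 1 sits within the scatter of it, so no ordering between them can be read. Compound 3 `C/C=C/C(=O)Nc1ccc(Cn2nc(-c3ccc(Oc4ccccc4)cc3)cc2C(=O)OCC)cc1` differs from compound 2 as follows: 4-(((prop-1-en-1-yl)carbonyl)amino)phenyl in place of 3-((vinylcarbonyl)amino)phenyl on a saturated chain carbon bound to an aromatic nitrogen. Among the compounds with values here, no step between measured compounds in this assay is available to lean on. The expected step is a 1.2-fold higher number from compound 2 to compound 3 (0.08 log units; within the scatter), small, toward a somewhat higher number, and within the scatter. Compound 3 is therefore estimated at 4000 nM, with a range from 1500 nM to 11000 nM.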

Compound 3, half-maximal inhibitory concentration: 13100 nM
Estimate against measurement, compound 3: 3.3-fold (0.52 log units) below; the measured number lies above the stated range.
By their numbers in this assay, from the lowest: compounds 2 and 1 (each within the scatter of the next); then compound 3.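

In this assay, the position on a saturated chain carbon bound to an aromatic nitrogen proves sensitive: 4-(((prop-1-en-1-yl)carbonyl)amino)phenyl in place of 3-((vinylcarbonyl)amino)phenyl gives a step beyond the scatter (a 4.0-fold higher number from compound 2 to compound 3 (0.60 log units; beyond the scatter)). This replacement alters both the amide's placement on the phenyl ring and the acyl group, so the step cannot be assigned to either change alone. Nothing available bears on the cause of the step.

Open: how 4-((vinylcarbonyl)amino)phenyl would stand at this position, and whether a saturated propanoyl amide would stay within the scatter of compound 2.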